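A methoxy added to compound 3 gives compound 4

The source may hold more compounds than are shown below. What is called first, only, known or untested is meant among the compounds shown, and "the series" means these compounds.

Compound 3 (`COc1ccc(-c2nc3cc(/C(C)=N/NC(N)=O)ccc3[nH]2)cc1`) offers no number to start from: in an ADME assay on Vero cells (Chlorocebus sabaeus) for cytotoxicity, read by MTT assay, with a stated time of 96 h (a lower number here means that less compound is tolerated, a higher number that more compound is tolerated), the entry for compound 3 reads "not determined" (no result reported). The two other values shown are both limits. Compound 1 (`COc1ccc(-c2nc3cc(C(C)=O)ccc3[nH]2)c(OC)c1`) gives > 100000 nM, which is a limit of the assay and not a number. Compound 2 (`COc1ccc(-c2nc3cc(/C(C)=N/O)ccc3[nH]2)c(OC)c1`) gives > 100000 nM, again a limit. Everything measured in this assay thus stands at the limit of > 100000 nM in this assay, at which 2 of the 3 values shown sit.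

Compound 4 (`COc1ccc(-c2nc3cc(/C(C)=N/NC(N)=O)ccc3[nH]2)c(OC)c1`) differs from compound 3 in one place: methoxy in place of hydrogen on an aromatic carbon, ortho to a large group and meta to a methoxy group. Compound 4 keeps the rest of compound 3 and gains a methoxy that compound 1 and compound 2 already carry. Among the measured compounds shown here, the only measured step, a step that the two limits leave unreadable from compound 1 to compound 2, lies elsewhere in the molecule and gives no size to carry over. The expectation leans instead on compound 2, whose > 100000 nM is a limit reached with this methoxy in place. For the measured compounds named here, no step of readable size is therefore expected in this assay, in either direction, although the lower end stays open since neither limit was measured with the chain of compound 3. For compound 4 the estimated value is 100000 nM, with an expected range from 30000 nM to 200000 nM.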

Compound 4, half-maximal cytotoxic concentration: 80000 nM
Beside the measured number, compound 4's estimate is 1.3-fold (0.10 log units) above it, and the stated range covers the measured number.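

In this assay compound 4 gives 80000 nM, the only number among the compounds shown that is not a limit, so a value can now be read for the ureido chain with the methoxy in place. Against the two compounds that carry the same methoxy, the change reads as an at least 1.2-fold lower number from compound 2 to compound 4 (0.09 log units; that floor lies within the scatter) and as an at least 1.2-fold lower number from compound 1 to compound 4 (0.09 log units; that floor lies within the scatter); these are floors, so the full size of each step is unknown, and neither shows on its own that ureido in place of hydroxy, or the larger group in place of the smaller one on the aromatic carbon, lowers the number. The scale against which compound 4 can be set is therefore still a ceiling of the assay and not a measured value: the limit of > 100000 nM in this assay, at which 2 of the 4 values shown sit.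

On these data alone, compound 3 has no result, so what the methoxy itself contributes at this position, ortho to a large group and meta to a methoxy group, stays open. Also open, as far as these compounds go, is whether an amine or a carboxylic acid in place of the ureido on the double-bonded nitrogen, or a longer chain there, would move the number beyond the usual scatter.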